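This account rests on a few compounds, and the source may have more. Where it says the series, first, only, none or still open, it means among the compounds named here.

Working notes on the oxime ether series built on the shared core of compound 3 `CCOC(=O)CO/N=C(/c1ccc(OC)c(OC)c1OC)c1cccc2ccccc12`. In a functional assay on MCF7 cells (Homo sapiens) for inhibition, read by sulforhodamine B assay, with a stated time of 48 h (a lower number here means a stronger inhibitor, a higher number a weaker inhibitor), compound 3 gives only a limit of the assay, > 20000 nM. Compound 1 `CCOC(=O)CCO/N=C(/c1ccc(OC)c(OC)c1OC)c1cccc2ccccc12` likewise reaches only the limit > 20000 nM. Compound 2 `COc1ccc(/C(=N/O)c2cccc3ccccc23)c(OC)c1OC` also stops at the limit > 20000 nM. All three sit at the limit of > 20000 nM in this assay, at which 3 of the 3 values shown sit, so the steps a step that the two limits leave unreadable from compound 1 to compound 3 and a step that the two limits leave unreadable from compound 2 to compound 3 give no readable size, and a step that the two limits leave unreadable from compound 1 to compound 2 none either. Compound 4 `CCOC(=O)/C=C/CO/N=C(/c1ccc(OC)c(OC)c1OC)c1cccc2ccccc12` differs from compound 3 by 2-(ethoxycarbonyl)ethenyl in place of ethoxycarbonyl on a saturated chain carbon bound to an oxygen on an unsaturated carbon. With every measured step hidden by the limit, no direction in this assay can be derived; the expected step from compound 3 to compound 4 is a step that the limit leaves unreadable from compound 3 to compound 4. Compound 4 is therefore estimated at 30000 nM, with an expected range from 8000 nM to 120000 nM.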

Compound 4, half-maximal inhibitory concentration: > 20000 nM
Compound 4: a limit, no number (the forecaster's own chance of this, stated with the estimate: 80%); the middle value lies beyond the limit too.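

Among these compounds, no step to compound 4 from compound 1, compound 2 or compound 3 can be read in this assay, where all four compounds give only a limit: the limit of > 20000 nM in this assay, at which 4 of the 4 values shown sit. The compounds shown leave open whether any group on the shared core gives a readable value.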